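One Hydroxy Swap on a Dichlorophenyl Analogue

A few compounds are considered here, and "the series" means these few. Any claim that something is new, unique, unknown or untested is made for them only; others in the source may bear on it.

Measured in a functional assay on A549 cells (Homo sapiens) for cytotoxicity, read by MTT assay, with a stated time of 72 h; a lower number here means a stronger inhibitor, a higher number a weaker inhibitor:
compound 1 `COc1ccccc1/C=C1\CCC/C(=C\c2ccc(OC)c(OC)c2)C1=O`: > 20000 nM (a limit of the assay)
compound 2 `COc1ccc(/C=C2\CCC/C(=C\c3ccc(Cl)cc3Cl)C2=O)cc1OC`: > 20000 nM (a limit of the assay)
compound 3 `COc1ccc(/C=C2\CCC/C(=C\c3cc(Cl)cc(Cl)c3)C2=O)cc1OC`: 5500 nM

Of these three, only compound 3 has a number rather than a limit. Two measured steps lead to it: an at least 3.6-fold lower number from compound 1 to compound 3 (0.56 log units; beyond the scatter), and an at least 3.6-fold lower number from compound 2 to compound 3 (0.56 log units; beyond the scatter). The remaining step is a step that the two limits leave unreadable from compound 1 to compound 2.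

Compound 4 `COc1ccc(/C=C2\CCC/C(=C\c3ccc(O)c(Cl)c3)C2=O)cc1OC` has not yet been measured. The change is 3-chloro-4-hydroxyphenyl in place of 3,5-dichlorophenyl on a double-bonded chain carbon bound to a double-bonded ring carbon, made on a double-bonded chain carbon bound to a double-bonded ring carbon. Going by the values given here, the steps to compound 3 show that exchanging this aryl group can shift the number in this assay, but no measured step exchanges a chlorine for a hydroxy group. No direction is therefore secure, and a result at the limit remains possible. Starting from compound 3 at 5500 nM, the expected outcome is a 1.3-fold higher number from compound 3 to compound 4 (0.10 log units; within the scatter). For compound 4 the estimated value is 7000 nM, with an expected range of 2500 nM to 20000 nM.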

Compound 4, half-maximal inhibitory concentration: > 20000 nM
Compound 4 gave a limit, no number (the forecaster's own chance of this, stated with the estimate: 25%); middle value at least 2.8-fold (0.45 log units) away from the limit.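

In this assay, the step to a hydroxy-bearing aryl group at this place is an at least 3.6-fold higher number from compound 3 to compound 4 (0.56 log units; beyond the scatter), and it lies beyond the scatter. Going by these compounds alone, the earlier steps exchanged only chlorine- and methoxy-bearing aryl groups, so this is the first sign that 3-chloro-4-hydroxyphenyl, which keeps one chlorine, does not preserve the measurable value of compound 3. The value of compound 4 is a limit of the assay, the steps to it from compound 1 and compound 2 cannot be read, and compound 3 remains the only one with a number: the limit of > 20000 nM in this assay, at which 3 of the 4 values shown sit.

The compounds shown do not separate the loss of the second chlorine from the entry of the hydroxy group. They also leave open whether a methoxy or an amino group in place of that hydroxy group would give a number.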